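Three amides measured, a fourth awaiting its number

The source may report more compounds than this note shows. Statements on the series, on what has been measured and on what is new or still open speak of the compounds shown alone.

Compound 1 `CCn1cc(C(=O)Nc2ccccc2O)c(=O)c2cc(F)c(N3CCNC(C)C3)c(F)c21`, compound 2 `CCn1cc(C(=O)Nc2ccc(Cl)cn2)c(=O)c2cc(F)c(N3CCNC(C)C3)c(F)c21` and compound 3 `CCn1cc(C(=O)Nc2ccc(C)c([N+](=O)[O-])c2)c(=O)c2cc(F)c(N3CCNC(C)C3)c(F)c21` share one core and differ only in the group carried on an amide-type nitrogen. In a functional assay on KB cells (Homo sapiens) for cytotoxicity, read by MTT assay (on this read-out lower numbers stand for stronger inhibition and higher numbers for weaker inhibition), compound 1 gives 5050 nM, compound 2 gives 1600 nM and compound 3 gives 3900 nM. Compound 3 thereby holds the second highest of the three numbers: one step of a 1.3-fold lower number from compound 1 to compound 3 (0.11 log units; within the scatter) stays within the scatter, while the other 2.4-fold higher number from compound 2 to compound 3 (0.39 log units; beyond the scatter) lies beyond it, though only modestly.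

Compound 4 `CCn1cc(C(=O)Nc2cc([N+](=O)[O-])ccc2F)c(=O)c2cc(F)c(N3CCNC(C)C3)c(F)c21` is the next member. It differs from compound 3 in one place: 2-fluoro-5-nitrophenyl in place of 4-methyl-3-nitrophenyl on an amide-type nitrogen. Going by the values given here, the steps that bear on this change are the two just described, one within the scatter and one of modest size, and neither exchanges one nitrophenyl group for another; nothing measured so far speaks directly to moving a nitro group and trading a methyl for a fluorine on the same ring. The account therefore expects in this assay no step beyond the scatter. Compound 4 is estimated to give about 3900 nM, with a range from 1500 nM to 10000 nM. The step of no change at the digits printed from compound 3 to compound 4 (within the scatter) is expected to remain within the usual scatter.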

Compound 4, half-maximal inhibitory concentration: 3200 nM
Compound 4: the middle estimate sits 1.2-fold (0.09 log units) above what was measured; the measured number falls inside the stated range.
By their numbers in this assay, from the lowest: compounds 2, 4, 3 and 1 (each within the scatter of the next, the first and the last beyond it).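

In this assay, going by these compounds alone, the change gives the first comparison of one nitrophenyl group with another on the amide-type nitrogen, and a 1.2-fold lower number from compound 3 to compound 4 (0.09 log units; within the scatter) shows that 2-fluoro-5-nitrophenyl and 4-methyl-3-nitrophenyl cannot be told apart at this position, even with a fluorine in place of a methyl and the nitro group at a different number on the ring. Compound 4 also lies within the scatter of the other two amides, as a 2.0-fold higher number from compound 2 to compound 4 (0.30 log units; within the scatter) and a 1.6-fold lower number from compound 1 to compound 4 (0.20 log units; within the scatter) show, although a 3.2-fold lower number from compound 1 to compound 2 (0.50 log units; beyond the scatter) separates those two, so the new group does not fall clearly on either side of that step. No measurement accompanies these numbers that could account for them.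

The compounds shown leave open what the nitro group itself contributes here, as both nitrophenyl amides carry a second group on the ring and no plain nitrophenyl or unsubstituted phenyl stands beside them for comparison. They also leave open whether an aminophenyl or a carboxyphenyl group on the amide-type nitrogen would give a number beyond the scatter of those seen so far.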